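The source may hold more compounds than are shown below. What is called first, only, known or untested is meant among the compounds shown, and "the series" means these compounds.

The study measures inhibition in an assay on HEK293 cells for inhibition of neurogenic locus notch homolog protein 1 (Homo sapiens), read by a luciferase reporter and resazurin assay, with a stated time of 16 h; a lower number here means a stronger inhibitor, a higher number a weaker inhibitor. Compound 1 `CC1=C(C(=O)OC2CCCCC2)C(c2cccc(C(F)(F)F)c2)C2=C(CC(C)(C)CC2=O)N1` gives 14700 nM, and compound 2 `CC1=C(C(=O)OCC2CCN(C(=O)OC(C)(C)C)CC2)[C@@H](c2cccc(Br)c2)C2=C(CC(C)(C)CC2=O)N1` gives 2590 nM. Compound 2 therefore stands with the lowest of the two numbers, and the gap to compound 1 lies beyond the scatter; the two compounds differ in more than one place, so nothing further is drawn from that gap.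

Compound 3 `CC1=C(C(=O)OCC2CCN(C(=O)OC(C)(C)C)CC2)C(c2cccc(Br)c2)C2=C(CC(C)(C)CC2=O)N1` is the next compound. It differs from compound 2 only in this: the two compounds have the same atoms and bonds; at least one stereo element is drawn with a configuration in one of them and without one in the other: 1 of 1 stereo elements differ; a stereocentre at a saturated ring carbon is drawn S in compound 2 and without a configuration in compound 3. Compound 3 thus holds the same atoms and bonds as compound 2 but without a drawn configuration at that carbon.

Among the compounds with values here, with no single-change step among the measured compounds, the expectation rests on compound 2 alone, whose value of 2590 nM sets the anchor. A modest shift toward a higher number is expected, a 1.7-fold higher number from compound 2 to compound 3 (0.24 log units; within the scatter), likely within the scatter. Compound 3 is thus estimated at 4500 nM, between 1500 nM and 13000 nM.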

Compound 3, half-maximal inhibitory concentration: 360 nM
Compound 3: middle estimate off by 13-fold (1.10 log units), on the high side; the whole stated range lies above it.
By their numbers in this assay, from the lowest: compound 3; then compound 2; then compound 1.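

At the saturated ring carbon, going from the drawn S configuration to no drawn configuration comes with a 7.2-fold lower number from compound 2 to compound 3 (0.86 log units; beyond the scatter) in this assay, while the atoms and bonds stay the same. Within the data shown here, this is the first gap that can be tied to a single place, since compound 1 and compound 2 differ in more than one, and it shows that the configuration recorded at this carbon matters to the reading. The structures do not tell whether compound 3 is a mixture or a single form, so the one difference that can be pointed to is this: the fact that one of compounds 2 and 3 is drawn with a defined configuration and the other without, at the place where they differ

On these data alone, how a form drawn R alone would read remains open. So does whether the same gap would hold with a free amine in place of the tert-butyl carbamate, or with a nitrile in place of the bromine.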